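Working notes on a two-step series

A few compounds are considered here, and "the series" means these few. Any claim that something is new, unique, unknown or untested is made for them only; others in the source may bear on it.

In a functional assay on the whole organism with Rattus norvegicus as the target, at a dose of 40 mg/kg by the intraperitoneal route (on this read-out lower numbers stand for less inhibition and higher numbers for more inhibition at the one dose given (going by the name of the read-out)), compound 2 `CCCNc1c(C)nc2c(OCc3ccccc3)cccn12` gives 99%, the highest of the two numbers measured; compound 1 `CNC(=O)Nc1c(C)nc2c(OCc3ccccc3)cccn12` gives 22%. For the measured compounds named here, the one measured step, a number 77 percentage points higher from compound 1 to compound 2 (beyond the scatter), alters the same nitrogen on an aromatic ring but by a different group, and does not bear directly on the present change. Compound 3 `CCCN(CCC)c1c(C)nc2c(OCc3ccccc3)cccn12` differs from compound 2 by propyl in place of hydrogen on a nitrogen on an aromatic ring. Going by the values given here, no measured step covers propyl in place of hydrogen here, and the number for compound 2 already sits close to the top of the read-out's range. The expected step is a number 9 percentage points lower from compound 2 to compound 3 (within the scatter), within the scatter. Compound 3 is estimated at 90%, with a range of 55% to 100%.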

Compound 3, a percentage reported as inhibition, in the whole organism at one dose (the size of the read-out at that dose, not a potency): 60%
Estimate against measurement, compound 3: 30 percentage points above; low and high end bracket the measured number.
By their numbers in this assay, from the lowest: compound 1; then compound 3; then compound 2.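

A second propyl on the nitrogen on an aromatic ring is not neutral: a number 39 percentage points lower from compound 2 to compound 3 (beyond the scatter) in this assay shows that propylamino to dipropylamino costs inhibition at this dose. Even so, a number 38 percentage points higher from compound 1 to compound 3 (beyond the scatter) places dipropylamino ahead of (methylcarbamoyl)amino on this aromatic carbon. No measurement shown accounts for the loss.

Open, as far as these compounds go, is whether a smaller second group such as methyl or ethyl would hold the number of compound 2 or lose it too. From the compounds shown here alone, a cyclic amine such as pyrrolidine on the same carbon also remains open.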